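Changing the Cyclic Amine on the Shared Core

This account rests on a few compounds, and the source may have more. Where it says the series, first, only, none or still open, it means among the compounds named here.

Measured so far:
compound 1, `COc1cc(OC)c2c(N3CCCC3)nc(-c3ccc(C(=O)NO)cc3)nc2c1`, in an assay on isolated protein for inhibition of protein deacetylase HDAC6 (Homo sapiens), tested at 0.5 uM (a lower number here means less inhibition, a higher number more inhibition at the concentration tested (going by the name of the read-out)), gives 55.3%
compound 2, `COc1cc(OC)c2c(N3CCCCC3)nc(-c3ccc(C(=O)NO)cc3)nc2c1`, in this assay gives 62.5%

For the measured compounds named here, compound 2 holds the higher of the two numbers, but its nearest neighbour is compound 1, and the single measured step, a number 7.2 percentage points higher from compound 1 to compound 2 (within the scatter), lies within the scatter, so the two compounds cannot be ordered. Compound 3, `COc1cc(OC)c2c(N3CCN(C)CC3)nc(-c3ccc(C(=O)NO)cc3)nc2c1`, differs from compound 2 by 4-methylpiperazin-1-yl in place of piperidin-1-yl on an aromatic carbon. Going by the values given here, the only step that bears on this change is the one from compound 1 to compound 2, which also swapped the cyclic amine on the shared core and stayed within the scatter. On that basis the step from compound 2 to compound 3 is expected to be small, a number 4.5 percentage points lower from compound 2 to compound 3 (within the scatter), with no direction beyond the scatter. Compound 3 is therefore estimated at 58% in this assay, with a range from 42% to 74%.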

Compound 3, a percentage reported as inhibition, at one concentration (the size of the read-out at that concentration, not a potency): 78.3%
Beside the measured number, compound 3's estimate is 20.3 percentage points below it, and the stated range ends below it.
By their numbers in this assay, from the lowest: compounds 1 and 2 (each within the scatter of the next); then compound 3.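

Unlike the earlier swap of pyrrolidin-1-yl for piperidin-1-yl, which did not separate compound 1 and compound 2, this change shows that the cyclic amine at this position can shift the read-out in this assay. Putting 4-methylpiperazin-1-yl here in place of piperidin-1-yl gives a number 15.8 percentage points higher from compound 2 to compound 3 (beyond the scatter), and in place of pyrrolidin-1-yl it gives a number 23 percentage points higher from compound 1 to compound 3 (beyond the scatter), so compound 3 stands clear of both other compounds. No measurement shown here accounts for this difference.

The compounds shown leave open whether the rise goes with the second hetero atom in the ring or with the methyl group that comes with it. An unsubstituted piperazin-1-yl or a morpholin-4-yl at this position would bear on that question.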